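Naphthalen-1-yl for phenyl: a lipophilicity expectation

The source may hold more compounds than are shown below. What is called first, only, known or untested is meant among the compounds shown, and "the series" means these compounds.

Measured so far:
compound 1 `CC(=N)Nc1cccc(C(=O)NNC(=O)CC(CC(=O)O)c2ccc(Cl)cc2)c1`, 2
compound 2 `N=C(N)Nc1cccc(C(=O)NNC(=O)NC(CC(=O)O)c2ccccc2)c1`, 0.7

In a physicochemical assay for lipophilicity (on this read-out higher numbers stand for higher lipophilicity and lower numbers for lower lipophilicity), compound 2 gives 0.7, the lower of the two numbers recorded. Going by the values given here, compound 1, the only other measured compound, gives 2 in this assay, and that gap lies beyond the usual scatter. Among the compounds with values here, the two differ in several places at once, so their values are simply stated side by side and no single step is read from them.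

Compound 3 `N=C(N)Nc1cccc(C(=O)NNC(=O)NC(CC(=O)O)c2cccc3ccccc23)c1` is not yet measured. It differs from compound 2 in one place: naphthalen-1-yl in place of phenyl on a saturated chain carbon bound to an amide-type nitrogen and a saturated chain carbon. The change brings in more ring carbon and adds no hydrogen-bond donor or acceptor, while leaving the rest of the shared core untouched. A rise in this assay is therefore expected, of a size clearly beyond the scatter, and the step expected is a number 1.20 log units higher from compound 2 to compound 3 (beyond the scatter). Compound 3 is thus estimated at 1.9, with a range from 1.4 to 2.4.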

Compound 3, partition coefficient: 1.7
Estimate against measurement, compound 3: 0.20 log units above, within the range that was stated.
By their numbers in this assay, from the lowest: compound 2; then compounds 3 and 1 (each within the scatter of the next).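

At the saturated chain carbon bound to an amide-type nitrogen and a saturated chain carbon, the series now has its first comparison that differs in one place. In this assay, naphthalen-1-yl in place of phenyl gives a number 1.00 log units higher from compound 2 to compound 3 (beyond the scatter), so the value at this position on the shared core does shift with the aromatic group it carries, and here the exchange puts two six-membered aromatic rings of carbon only where one stood, with no hydrogen-bond donor or acceptor on either side. Nothing at hand bears on why the step has this size.

One replacement at one position cannot separate the effect of the second ring from that of the way it is attached, and naphthalen-2-yl, benzyl or cyclohexyl on the same carbon would help to tell these apart. It also remains open whether the exchange would give a similar step with the carboxylic acid replaced by its methyl ester, or with a longer chain carrying the acid, as every compound shown has the same free acid.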